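The source may report more compounds than this note shows. Statements on the series, on what has been measured and on what is new or still open speak of the compounds shown alone.

Measured so far in an assay for binding affinity to dual specificity mitogen-activated protein kinase kinase 4 (Homo sapiens), read by KINOMEscan, tested at 10 nM; on this read-out lower numbers stand for a stronger effect and higher numbers for a weaker effect at the one concentration tested:
- compound 1 `CCCS(=O)(=O)Nc1ccc(F)c(C(=O)c2n[nH]c3ncc(-c4ccc(S(=O)(=O)NCC)cc4)cc23)c1F`: 41%
- compound 2 `CCCS(=O)(=O)Nc1ccc(F)c(C(=O)c2n[nH]c3ncc(-c4ccc(C(=O)O)cc4)cc23)c1F`: 0.2%

Compound 2 stands lowest of the two numbers in this assay; its nearest neighbour is compound 1, higher by the step of a number 40.8 percentage points lower from compound 1 to compound 2 (beyond the scatter) taken the other way. Compound 3 `CCCS(=O)(=O)Nc1ccc(F)c(C(=O)c2n[nH]c3ncc(-c4ccc(S(N)(=O)=O)cc4C)cc23)c1F` is not yet measured. It differs from compound 2 in one place: 2-methyl-4-sulfamoylphenyl in place of 4-carboxyphenyl on an aromatic carbon. Among the compounds with values here, the only measured step that bears on this change is a number 40.8 percentage points lower from compound 1 to compound 2 (beyond the scatter), which was large and beyond the scatter, and which took an ethylsulfamoyl group off the same aromatic carbon in favour of carboxy. Within the data shown here, compound 3 brings a sulfamoyl group back onto that carbon, with a methyl added, so the expected step in this assay is upward, of a size comparable to that measured step; the added methyl has no measured precedent here, so the range is kept wide. The estimated step is a number 24.8 percentage points higher from compound 2 to compound 3 (beyond the scatter). For compound 3 the expected value in this assay is 25%, with a range from 3% to 65%.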

Compound 3, a percentage reported as activity, at one concentration (the size of the read-out at that concentration, not a potency): 24%
Estimate against measurement, compound 3: 1 percentage points above, and the stated range covers the measured number.
By their numbers in this assay, from the lowest: compound 2; then compound 3; then compound 1.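

In this assay, 2-methyl-4-sulfamoylphenyl in place of 4-carboxyphenyl on this aromatic carbon gives a number 23.8 percentage points higher from compound 2 to compound 3 (beyond the scatter), so this replacement does not keep the low number seen with carboxy. Against the 4-(ethylsulfamoyl)phenyl group, the same 2-methyl-4-sulfamoylphenyl group gives a number 17 percentage points lower from compound 1 to compound 3 (beyond the scatter), which shows that the read-out also shifts between the two sulfamoyl-bearing groups and places compound 3 between compound 2 and compound 1. No supporting data are available to explain either step.

The step to compound 3 removes the ethyl group and adds the methyl group together, leaving the share of each unresolved. On these data alone, how a primary amide or an amine would compare with the carboxy group on the same phenyl ring remains open.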